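Methoxy for fluoro on the fused ring of compound 2

The source may report more compounds than this note shows. Statements on the series, on what has been measured and on what is new or still open speak of the compounds shown alone.

Measured compounds:
compound 1 `Cc1ccc(-c2ccc(F)cc2)n1-c1ccc(-c2nc3ccccc3s2)cc1`: 4340 nM
compound 2 `Cc1ccc(-c2ccc(F)cc2)n1-c1ccc(-c2nc3ccc(F)cc3s2)cc1`: 3030 nM
compound 3 `COc1ccc(-c2ccc(C)n2-c2ccc(-c3nc4ccc(F)cc4s3)cc2)cc1`: 3070 nM

In a functional assay on MDA-MB-231 cells (Homo sapiens) for cytotoxicity, read by sulforhodamine B assay, with a stated time of 48 h (on this read-out lower numbers stand for stronger inhibition of growth and higher numbers for weaker inhibition of growth), compound 2 sits within the scatter of both others: the step of a 1.4-fold lower number from compound 1 to compound 2 (0.16 log units; within the scatter) and the step of a 1.0-fold higher number from compound 2 to compound 3 (0.01 log units; within the scatter) are each small. Compound 4 `COc1ccc2nc(-c3ccc(-n4c(C)ccc4-c4ccc(F)cc4)cc3)sc2c1` is not yet measured. It differs from compound 2 by methoxy in place of fluoro on an aromatic carbon. The step from compound 2 to compound 3, the same exchange made elsewhere in the molecule, was a 1.0-fold higher number from compound 2 to compound 3 (0.01 log units; within the scatter), and the change of the substituent on the fused ring from compound 1 to compound 2 was a 1.4-fold lower number from compound 1 to compound 2 (0.16 log units; within the scatter). Neither bears a change beyond the scatter, so for compound 4 the expected step is a 1.1-fold higher number from compound 2 to compound 4 (0.02 log units; within the scatter). Compound 4 is therefore estimated at 3200 nM, between 1600 nM and 6400 nM.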

Compound 4, concentration for 50% growth inhibition: 4060 nM
For compound 4 the middle estimate is 1.3-fold (0.10 log units) below the measured one; low and high end bracket the measured number.
By their numbers in this assay, from the lowest: compounds 2, 3, 4 and 1 (each within the scatter of the next).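

At this position on the fused ring, this assay now covers hydrogen, fluoro and methoxy. Methoxy in place of fluoro gives a 1.3-fold higher number from compound 2 to compound 4 (0.13 log units; within the scatter) and methoxy in place of hydrogen gives a 1.1-fold lower number from compound 1 to compound 4 (0.03 log units; within the scatter), so neither exchange at this position moves the number beyond the scatter, as the fluoro to methoxy exchange elsewhere in the molecule also did not. No evidence is available to explain this result. As far as these compounds go, whether an amine or a carboxylic acid on this carbon would give a step beyond the scatter remains open. So does whether these small steps would hold in other cell lines.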